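This account rests on a few compounds, and the source may have more. Where it says the series, first, only, none or still open, it means among the compounds named here.

Among the compounds with values here, compound 1 `COC[C@H]1CN(c2ccn(C)c2)C(=O)O1` is the weakest of the three measured members: in an assay for inhibition of Amine oxidase [flavin-containing] A (Bos taurus), read by fluorescence, with a stated time of 30 min (a lower number here means a stronger inhibitor, a higher number a weaker inhibitor), compound 1 gives 300 nM, while compound 2 `CCn1ccc(N2C[C@H](COC)OC2=O)c1` gives 0.6 nM and compound 3 `C=CCn1ccc(N2C[C@H](COC)OC2=O)c1` gives 1 nM. The large steps seen so far, a 500-fold lower number from compound 1 to compound 2 (2.70 log units; beyond the scatter) and a 300-fold lower number from compound 1 to compound 3 (2.48 log units; beyond the scatter), concern the substituent on the aromatic nitrogen only. Compound 4 `Cn1ccc(N2C[C@H](CN=[N+]=[N-])OC2=O)c1` differs from compound 1 at another place: azido in place of methoxy on a saturated chain carbon bound to a saturated ring carbon. Within the data shown here, no measured step touches that position, so the three measured compounds give no direct guide to the size or direction of this change. On that basis the step of no change at the digits printed from compound 1 to compound 4 (within the scatter) is expected to stay within the scatter, with a wide margin. Compound 4 is accordingly estimated at 300 nM, between 60 nM and 1500 nM.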

Compound 4, inhibition constant: 200 nM
Compound 4: the middle estimate sits 1.5-fold (0.18 log units) above what was measured; the measured number falls inside the stated range.
By their numbers in this assay, from the lowest: compounds 2 and 3 (each within the scatter of the next); then compounds 4 and 1 (each within the scatter of the next).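

In this assay, within the data shown here, azido in place of methoxy on a saturated chain carbon bound to a saturated ring carbon gives a 1.5-fold lower number from compound 1 to compound 4 (0.18 log units; within the scatter) and so offers the first reading at this position. Unlike the large steps at the substituent on the aromatic nitrogen, this exchange leaves the number within the scatter. Nothing at hand explains this result.

From the compounds shown here alone, it remains open whether an amine, a hydroxyl or a longer chain at this place would also stay within the scatter. Going by these compounds, it is equally open whether azido would do so on compound 2 or compound 3.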